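A few compounds are considered here, and "the series" means these few. Any claim that something is new, unique, unknown or untested is made for them only; others in the source may bear on it.

Of the compounds shown here, three built on one shared core have been tested in a functional assay on C6 cells (Rattus norvegicus) for cytotoxicity, read by MTT assay, with a stated time of 24 h, tested at 200 ug/mL; on this read-out lower numbers stand for a stronger effect and higher numbers for a weaker effect at the one concentration tested. Compound 1 `Cn1nnnc1SCC(=O)N/N=c1/scc(-c2ccccc2)n1-c1ccccc1` gives 26.8%. Compound 2 `O=C(CSc1ncccn1)N/N=c1/scc(-c2ccc(F)cc2)n1-c1ccccc1` gives 32.2%. Compound 3 `O=C(CSc1nnnn1-c1ccccc1)N/N=c1/scc(-c2ccccc2)n1-c1ccccc1` gives 22.6%. Among these three, compound 3 carries the lowest number, yet its distance to each of the others lies within the scatter: the one measured step, a number 4.2 percentage points lower from compound 1 to compound 3 (within the scatter), is too small to trust, and the value of compound 2 sits close as well. The next compound, compound 4 `O=C(CSc1nnnn1-c1ccccc1)N/N=c1/scc(-c2ccc(Br)cc2)n1-c1ccccc1`, differs from compound 3 by bromo in place of hydrogen on an aromatic carbon. Within the data shown here, no measured step covers this exact change. The nearest hint comes from two compounds that also differ in the group attached through sulfur, so only their two values can be compared: compound 1, carrying hydrogen on that ring, gives 26.8%, while compound 2, carrying fluoro on that ring, gives 32.2%, a gap that stays within the scatter. On this slim basis the expected step in this assay is a number 1.4 percentage points higher from compound 3 to compound 4 (within the scatter), meaning no shift beyond the scatter is anticipated. Compound 4 is therefore estimated at 24%, with a likely range from 14% to 36%.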

Compound 4, a percentage reported as activity, at one concentration (the size of the read-out at that concentration, not a potency): 20.4%
Compound 4: the middle estimate sits 3.6 percentage points above what was measured; low and high end bracket the measured number.
By their numbers in this assay, from the lowest: compounds 4, 3, 1 and 2 (each within the scatter of the next, the first and the last beyond it).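

Read in this assay, the change from phenyl to 4-bromophenyl gives a number 2.2 percentage points lower from compound 3 to compound 4 (within the scatter). Among these compounds, this is the first direct look at this ring with the rest of the molecule held constant, since the earlier hint came from two compounds that also differed in the group attached through sulfur. It shows that placing one bromo on this aromatic carbon, para to a large group, causes no shift that can be told apart from the scatter at the single concentration tested, and no other measurement offers an explanation for this result.

A single substitution cannot show whether this position is insensitive to change in general, so an amine, a carboxylic acid or a longer chain in the same place could still move the number beyond the scatter. Going by these compounds, it also remains open whether bromo would have the same small effect on compound 1 , which carries methyl rather than phenyl on the aromatic nitrogen of its sulfur-linked group.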